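Compound 4: trifluoromethyl in place of trifluoromethoxy

This account rests on a few compounds, and the source may have more. Where it says the series, first, only, none or still open, it means among the compounds named here.

Measured in a functional assay on HL-60 cells (Homo sapiens) for cytotoxicity, read by luminescence and CellTiter-Glo, with a stated time of 3 days; on this read-out lower numbers stand for stronger inhibition and higher numbers for weaker inhibition:
- compound 1 `O=C(Nc1ccc(C(F)(F)F)cc1)c1cc(Cl)ccc1O`: 510 nM
- compound 2 `N#Cc1ccc(NC(=O)c2cc(F)ccc2O)cc1`: 1420 nM
- compound 3 `O=C(Nc1ccc(OC(F)(F)F)cc1)c1cc(F)ccc1O`: 850 nM

Compound 3 gives 850 nM, within the scatter of both compound 1 and compound 2. Compound 4 `O=C(Nc1ccc(C(F)(F)F)cc1)c1cc(F)ccc1O` changes one group: trifluoromethyl in place of trifluoromethoxy on an aromatic carbon, para to a large group. Within the data shown here, the one measured step at this place, a 1.7-fold lower number from compound 2 to compound 3 (0.22 log units; within the scatter), puts trifluoromethoxy in place of cyano and stays within the scatter. Among the measured compounds shown here, compound 1, which also carries trifluoromethyl, gives 510 nM, but no measured step links it to compound 4. No step beyond the scatter is therefore expected in this assay. The expected step is a 1.2-fold lower number from compound 3 to compound 4 (0.08 log units; within the scatter), within the scatter. For compound 4 the estimated value is 700 nM, with an expected range of 350 nM to 1400 nM.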

Compound 4, half-maximal inhibitory concentration: 490 nM
Compound 4: the middle estimate sits 1.4-fold (0.15 log units) above what was measured, within the range that was stated.
By their numbers in this assay, from the lowest: compounds 4, 1, 3 and 2 (each within the scatter of the next, the first and the last beyond it).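

In this assay, among these compounds, on this aromatic carbon, trifluoromethyl in place of cyano gives a 2.9-fold lower number from compound 2 to compound 4 (0.46 log units; beyond the scatter) and is the first step here beyond the scatter, while trifluoromethyl in place of trifluoromethoxy gives a 1.7-fold lower number from compound 3 to compound 4 (0.24 log units; within the scatter) and does not separate the two groups. Fluoro in place of chloro, a change elsewhere on the core, gives a 1.0-fold lower number from compound 1 to compound 4 (0.02 log units; within the scatter) and also does not separate the two halogens. No measurement bears on the reason for these steps. On these data alone, whether an amine, a carboxylic acid or a longer chain on this carbon would stay within the scatter of compound 4 remains open.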